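Shortening the butoxy chain to ethoxy in compound 3

The source may report more compounds than this note shows. Statements on the series, on what has been measured and on what is new or still open speak of the compounds shown alone.

In a functional assay on PC-3 cells (Homo sapiens) for cytotoxicity, read by MTT assay, with a stated time of 72 h (a lower number here means a stronger inhibitor, a higher number a weaker inhibitor), compound 1 (`[O-][n+]1nc(NCOCc2ccc(C(F)(F)F)cc2)[n+]([O-])c2ccccc21`) gives 7650 nM and compound 2 (`CCCCOCNc1n[n+]([O-])c2ccccc2[n+]1[O-]`) gives 14700 nM as its reading. These two numbers stand within the usual scatter of each other, and neither can be placed ahead of the other. Compound 3 (`CCOCNc1n[n+]([O-])c2ccccc2[n+]1[O-]`) remains unmeasured. It differs from compound 2 in one place, where butoxy becomes ethoxy: hydrogen in place of ethyl on a saturated chain carbon, two bonds along the chain from an oxygen on a saturated carbon with hydrogen in place of ethyl on a saturated chain carbon, two bonds along the chain from an oxygen on a saturated carbon. Compound 1 (7650 nM) and compound 2 (14700 nM) differ far more in structure than this, yet their numbers do not separate beyond the scatter. In this assay only a slight drift toward a weaker inhibitor is therefore expected, with no step beyond the scatter. The expected change is a 1.2-fold higher number from compound 2 to compound 3 (0.09 log units; within the scatter) and no more. For compound 3 the estimated value is 18000 nM with an expected range from 8000 nM to 40000 nM as its likely span.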

Compound 3, half-maximal inhibitory concentration: 15900 nM
For compound 3 the middle estimate is 1.1-fold (0.05 log units) above the measured one, within the range that was stated.
By their numbers in this assay, from the lowest: compounds 1, 2 and 3 (each within the scatter of the next, the first and the last beyond it).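

In this assay, the step at this position reads a 1.1-fold higher number from compound 2 to compound 3 (0.03 log units; within the scatter). Going by these compounds alone, this is the first comparison of two compounds that differ in one place, and it shows that replacing butoxy with ethoxy, with hydrogen in place of ethyl on a saturated chain carbon, gives no change that can be separated from the scatter. No measurement shown accounts for this result.

The compounds shown leave open whether the chain matters at all at this position, as this single step covers only butoxy and ethoxy. On these data alone, it remains unknown whether a longer chain such as hexyloxy, a shorter methoxy, or an amine or a carboxylic acid in place of the ethoxy would move the reading beyond the scatter.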